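Fluoro to nitro in the aroyl series: working notes

This account rests on a few compounds, and the source may have more. Where it says the series, first, only, none or still open, it means among the compounds named here.

Measured in a functional assay on MCF7 cells (Homo sapiens) for cytotoxicity, read by MTT assay, with a stated time of 96 h; on this read-out higher numbers stand for weaker inhibition and lower numbers for stronger inhibition:
Compound 1 `COc1cccc(-c2cn(-c3ccccc3)cc2C(=O)c2cc(OC)c(OC)c(OC)c2)c1`: 180 nM
Compound 2 `COc1cc(C(=O)c2cn(-c3cccc(C)c3)cc2-c2ccccc2F)cc(OC)c1OC`: 190 nM

In this assay compound 2 at 190 nM lies within the scatter of compound 1 at 180 nM, so the two cannot be told apart on these numbers. The next compound, compound 3 `COc1cc(C(=O)c2cn(-c3cccc(C)c3)cc2-c2ccccc2[N+](=O)[O-])cc(OC)c1OC`, carries nitro in place of fluoro on an aromatic carbon, ortho to a large group, which reads as 2-fluorophenyl to 2-nitrophenyl (nitro in place of fluoro on an aromatic carbon). Within the data shown here, no measured pair here isolates a single change, so the expectation is anchored only on compound 2 at 190 nM and on the structural change. A small move towards weaker inhibition is expected in this assay, and it may well stay within the scatter. The estimated size is a 1.4-fold higher number from compound 2 to compound 3 (0.14 log units; within the scatter). For compound 3 the expected value is 260 nM, with an estimated range of 80 nM to 850 nM.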

Compound 3, half-maximal inhibitory concentration: 220 nM
Compound 3: the middle estimate sits 1.2-fold (0.07 log units) above what was measured; low and high end bracket the measured number.
By their numbers in this assay, from the lowest: compounds 1, 2 and 3 (each within the scatter of the next).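

In this assay, among these compounds, the exchange of fluoro for nitro on an aromatic carbon, ortho to a large group, gives a 1.2-fold higher number from compound 2 to compound 3 (0.06 log units; within the scatter) and provides the only single-place comparison so far. At this position, the read-out does not separate the 2-fluorophenyl group of compound 2 from the 2-nitrophenyl group of compound 3, even though nitro brings more heavy atoms and hydrogen-bond acceptors. No measurement of any property of these compounds bears on this result.

As far as these compounds go, whether an amine or a carboxylic acid at this position would give a number beyond the scatter remains open. Compound 1 differs from compound 2 in more than one place, so it adds no reading on this position.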